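A few compounds are considered here, and "the series" means these few. Any claim that something is new, unique, unknown or untested is made for them only; others in the source may bear on it.

In an ADME assay on CCRF-CEM cells (Homo sapiens) for antiproliferative activity, with a stated time of 48 h (a higher number here means a weaker inhibitor, a lower number a stronger inhibitor), three compounds sharing one core have been measured. Compound 1 `C=C(Br)C(=O)Nc1ccc(/C=C/C(=O)c2ccccc2)cc1` reads 4000 nM while compound 2 `C=C(Br)C(=O)Nc1ccc(/C=C/C(=O)c2ccc(F)cc2)cc1` reads 1100 nM on the same scale. Compound 3 `Nc1ccc(/C=C/C(=O)c2ccccc2)cc1` has hydrogen in place of (1-bromoethenyl)carbonyl on a nitrogen and reads 34000 nM as the highest number of the three, which makes it the weakest inhibitor among them. Its nearest neighbour is compound 1, and the modest step of an 8.5-fold higher number from compound 1 to compound 3 (0.93 log units; beyond the scatter) separates the two.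

Compound 4 `Nc1ccc(/C=C/C(=O)c2ccc(F)cc2)cc1` is compound 3 with fluoro in place of hydrogen on an aromatic carbon. Going by the values given here, the one measured step with this same change is a 3.6-fold lower number from compound 1 to compound 2 (0.56 log units; beyond the scatter) and it is also modest. That step was seen with the (1-bromoethenyl)carbonyl group present. Among the compounds with values here, the group is absent from compound 3 and compound 4, so no measured step shows the fluoro change without it, and the earlier step may not carry over in full. The expected change is a 2.4-fold lower number from compound 3 to compound 4 (0.39 log units; beyond the scatter) in the same direction as that step but somewhat smaller. Compound 4 is therefore estimated at 14000 nM with an expected range from 6000 nM to 32000 nM as its upper end.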

Compound 4, half-maximal inhibitory concentration: 39000 nM
Compound 4: middle estimate off by 2.8-fold (0.44 log units), on the low side, and the stated range ends below it.
By their numbers in this assay, from the lowest: compound 2; then compound 1; then compounds 3 and 4 (each within the scatter of the next).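

In this assay, the fluoro para to a large group has a readable effect only when the (1-bromoethenyl)carbonyl group sits on the nitrogen: with hydrogen on the nitrogen instead, the step is a 1.1-fold higher number from compound 3 to compound 4 (0.06 log units; within the scatter), so the fluoro makes no readable difference on that core. The effect of this single-atom change therefore does not carry from one core to the other, and the gap between the two fluoro steps is larger than chance scatter would readily give: the same change on two cores in this assay, a 3.6-fold lower number (0.56 log units; beyond the scatter) from compound 1 to compound 2 and a 1.1-fold higher number (0.06 log units; within the scatter) from compound 3 to compound 4, 4.2-fold (0.62 log units) apart, beyond the scatter of two such steps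

Seen from the other side, removing the (1-bromoethenyl)carbonyl group costs more when the fluoro is present, at a 35-fold higher number from compound 2 to compound 4 (1.55 log units; beyond the scatter), so the two changes do not simply add up: the same change on two cores in this assay, an 8.5-fold higher number (0.93 log units; beyond the scatter) from compound 1 to compound 3 and a 35-fold higher number (1.55 log units; beyond the scatter) from compound 2 to compound 4, 4.2-fold (0.62 log units) apart, beyond the scatter of two such steps

These four compounds form only one such square, so they cannot show whether another group at this place, such as chloro or methoxy, would also act only alongside the (1-bromoethenyl)carbonyl group. Going by these compounds, it also remains open whether the fluoro would keep its effect with a different group on the nitrogen, such as a plain acetyl.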